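Series notes: N-aryl benzimidazolyl ureas, switch of the N-aryl group

The compounds below may be only part of what the source reports. "The series", "measured", "known", "first", "only" and "open" are said of these compounds alone.

Measured so far:
compound 1, `CC(C)c1cccc(C(C)C)c1NC(=O)Nc1nc2ccccc2n1-c1ccccc1Cl`, 18 nM
compound 2, `CC(C)c1cccc(C(C)C)c1NC(=O)Nc1nc2ccccc2n1-c1c(Cl)cccc1Cl`, 11 nM

Both compounds were run in an assay on isolated protein for displacement of a labelled ligand from acyl-CoA:cholesterol acyltransferase (Oryctolagus cuniculus); on this read-out higher numbers stand for weaker inhibition and lower numbers for stronger inhibition. Going by the values given here, compound 2 carries the lower of the two numbers, but the single step between them, a 1.6-fold lower number from compound 1 to compound 2 (0.21 log units; within the scatter), is a change of chloro in place of hydrogen on an aromatic carbon, and it lies within the scatter, so the two compounds are not separated on this read-out.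

Compound 3, `CC(C)c1cccc(C(C)C)c1NC(=O)Nc1nc2ccccc2n1-c1ccccc1N(C)C`, is the next member. Its difference from compound 2 is 2-(dimethylamino)phenyl in place of 2,6-dichlorophenyl on an aromatic nitrogen. Among the compounds with values here, no measured step covers this swap: the one known step only adds a second chloro to the same ring and does not move the number beyond the scatter. Within the data shown here, whether removing both chlorines and bringing in the dimethylamino substituent changes anything therefore rests on no direct precedent; the expectation is a modest shift at most, with a slight lean toward a higher number, the step of a 2.7-fold higher number from compound 2 to compound 3 (0.44 log units; beyond the scatter) being expected. For compound 3 the estimate in this assay is 30 nM, within a range from 8 nM to 120 nM.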

Compound 3, half-maximal inhibitory concentration: 41 nM
The estimate for compound 3 lay 1.4-fold (0.14 log units) below the measured number, and the stated range covers the measured number.
By their numbers in this assay, from the lowest: compounds 2 and 1 (each within the scatter of the next); then compound 3.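

In this assay, going by these compounds alone, the group on the aromatic nitrogen now moves the number, since a 3.7-fold higher number from compound 2 to compound 3 (0.57 log units; beyond the scatter) is the first step in this set to lie beyond the scatter, with 2-(dimethylamino)phenyl in place of 2,6-dichlorophenyl. The simpler comparison, dimethylamino in place of chloro on an aromatic carbon, shows the same direction: a 2.3-fold higher number from compound 1 to compound 3 (0.36 log units; beyond the scatter) marks this position as sensitive to the identity of the group on the aryl ring, where the added chloro of compound 2 had shown no separation from compound 1, though both new steps remain modest. Nothing available bears on why the number shifts with this swap.

The compounds shown leave open whether this shift is specific to dimethylamino or would also appear with a plain amino group, a methoxy group or an unsubstituted phenyl ring on the aromatic nitrogen. Also open, going by these compounds, is whether a chloro added to the 2-(dimethylamino)phenyl ring would leave the number within the scatter, as it does from compound 1 to compound 2 on the chlorinated ring.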